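A few compounds are considered here, and "the series" means these few. Any claim that something is new, unique, unknown or untested is made for them only; others in the source may bear on it.

Measured compounds:
- compound 1, `CN(C)c1ccc(N2C(=O)NC3(CSC4=C3C(=O)c3ncccc3C4=O)C2=O)cc1`: 800 nM
- compound 2, `O=C1C2=C(C(=O)c3ncccc31)C1(CS2)NC(=O)N(c2ccc([N+](=O)[O-])cc2)C1=O`: 1030 nM
- compound 3, `O=C1C2=C(C(=O)c3ncccc31)C1(CS2)NC(=O)N(c2ccccc2)C1=O`: 1510 nM

All three share one core and differ only in the group on the aromatic carbon of the phenyl ring attached to the imide nitrogen. In a functional assay on XF498 cells (Homo sapiens) for antiproliferative activity, read by MTT assay, with a stated time of 96 h (a higher number here means a weaker inhibitor, a lower number a stronger inhibitor), compound 1 gives the lowest of the three numbers, but the step of a 1.3-fold higher number from compound 1 to compound 2 (0.11 log units; within the scatter) and the step of a 1.9-fold higher number from compound 1 to compound 3 (0.28 log units; within the scatter) are both small, as is a 1.5-fold higher number from compound 2 to compound 3 (0.17 log units; within the scatter). So far, swapping dimethylamino for nitro or for hydrogen at this carbon has not moved the read-out beyond what repeat measurements would show.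

Compound 4, `CCCCCc1ccc(N2C(=O)NC3(CSC4=C3C(=O)c3ncccc3C4=O)C2=O)cc1`, is the next step from compound 1: pentyl in place of dimethylamino on an aromatic carbon. Going by the values given here, no measured step involves a pentyl group, so the three steps above bear on it only indirectly: they show that this position has tolerated three quite different groups with no change beyond the scatter. Compound 4 is therefore expected to give a number close to that of compound 1, with the estimated step of a 1.4-fold higher number from compound 1 to compound 4 (0.14 log units; within the scatter) lying within the scatter. The estimate for compound 4 in this assay is 1100 nM, with a range from 500 nM to 2500 nM.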

Compound 4, half-maximal inhibitory concentration: 830 nM
Beside the measured number, compound 4's estimate is 1.3-fold (0.12 log units) above it, within the range that was stated.
By their numbers in this assay, from the lowest: compounds 1, 4, 2 and 3 (each within the scatter of the next).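

In this assay, pentyl sits on this aromatic carbon with no step beyond the scatter against dimethylamino (a 1.0-fold higher number from compound 1 to compound 4 (0.02 log units; within the scatter)), hydrogen (a 1.8-fold lower number from compound 3 to compound 4 (0.26 log units; within the scatter)) or nitro (a 1.2-fold lower number from compound 2 to compound 4 (0.09 log units; within the scatter)). The new information lies in the kind of group: pentyl is an all-carbon chain of 5 heavy atoms, while dimethylamino has 3 heavy atoms, including a nitrogen, so the tolerance seen so far at this position now extends to a larger group with no hydrogen-bond acceptor, and none of the four compounds stands apart from the others in this read-out. No measurement is available to explain why the read-out stays so similar across these groups.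

The compounds shown leave open whether a much longer chain such as decyl, a carboxylic acid or a primary amine on this same carbon would also stay within the scatter. They also leave open whether a group that shifts the number beyond the scatter exists at all at this carbon, and whether the same tolerance would hold on other cell lines.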